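The source may hold more compounds than are shown below. What is called first, only, known or untested is meant among the compounds shown, and "the series" means these compounds.

Measured compounds:
compound 1, `c1ccc(-c2cn3ccnc3c(-c3ccc4ncn(C5CCCCC5)c4c3)n2)cc1`, 54.4% in a functional assay on MDA-MB-468 cells (Homo sapiens) for inhibition, read by sulforhodamine B assay, with a stated time of 48 h, tested at 10 uM; a lower number here means less inhibition, a higher number more inhibition at the concentration tested (going by the name of the read-out)
compound 2, `CC(=O)c1ccc(-c2cn3ccnc3c(-c3ccc4ncn(C5CCCCC5)c4c3)n2)cc1`, 0.73% in this assay

Compound 1 stands highest of the two numbers in this assay; its nearest neighbour is compound 2, which sits well below it, a number 53.7 percentage points lower from compound 1 to compound 2 (beyond the scatter). That step, acetyl in place of hydrogen on an aromatic carbon, is the only one in the series and it is large.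

Compound 3, `Clc1ccc(-c2cn3ccnc3c(-c3ccc4ncn(C5CCCCC5)c4c3)n2)cc1`, is not yet measured in this assay. It differs from compound 1 as follows: chloro in place of hydrogen on an aromatic carbon. Going by the values given here, the one measured step concerns acetyl, a different group at the same aromatic carbon, so it bears on the present change only loosely; it shows that the number at this position can fall by a large amount, but gives no reading for chloro. The expected step is therefore uncertain, a number 14.4 percentage points lower from compound 1 to compound 3 (beyond the scatter), with a wide range. Compound 3 is estimated at 40%, between 5% and 70%.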

Compound 3, a percentage reported as inhibition, at one concentration (the size of the read-out at that concentration, not a potency): 10.6%
Estimate against measurement, compound 3: 29.4 percentage points above; low and high end bracket the measured number.
By their numbers in this assay, from the lowest: compounds 2 and 3 (each within the scatter of the next); then compound 1.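

In this assay, the large loss seen with acetyl is not confined to that group: chloro at the same aromatic carbon, para to a large group, gives a number 43.8 percentage points lower from compound 1 to compound 3 (beyond the scatter). The two substituents are not separated here, since chloro in place of acetyl gives a number 9.9 percentage points higher from compound 2 to compound 3 (within the scatter), so among these compounds only the unsubstituted phenyl of compound 1 keeps a substantial reading, and both substituents on this carbon go with a low one. Nothing at hand explains the loss with either group.

Open, from the compounds shown here alone, is whether any group at this carbon retains the level of compound 1, for example fluoro, methyl, an amine or a carboxylic acid. Readings at a single concentration also leave the potency of these compounds undefined.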